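The source may hold more compounds than are shown below. What is called first, only, known or untested is meant among the compounds shown, and "the series" means these compounds.

Working notes on the series. In a functional assay on JeKo-1 cells (Homo sapiens) for inhibition, read by luminescence and CellTiter-Glo, with a stated time of 72 h (on this read-out higher numbers stand for weaker inhibition and lower numbers for stronger inhibition), compound 1 `O=C(CCl)N1CCCC(n2nc(-c3ccc(Oc4ccccc4)cc3)cc2CO)C1` gives 7800 nM. Compound 2 `C=CC(=O)Nc1ccc(Cn2nc(-c3ccc(Oc4ccccc4)cc3)cc2C(=O)O)cc1` is built on a related core with a different arm. For compound 2 this assay returns only a limit, > 60000 nM, so no number stands for it. One of the two values thus sits at the limit of > 60000 nM in this assay, at which 1 of the 2 values shown sits, leaving one measured number and one limit. Compound 3 `C/C=C/C(=O)Nc1ccc(Cn2nc(-c3ccc(Oc4ccccc4)cc3)cc2C(=O)O)cc1` is to be measured in this assay. The change is prop-1-en-1-yl in place of vinyl on a carbonyl carbon, the rest of compound 2 kept. Going by the values given here, no measured pair differs in this way, so no step is on hand to scale it. Compound 2 stands at a limit, and the expected step of a number no higher from compound 2 to compound 3 (the limit leaves the size open) is accordingly set at no change, not placeable within or beyond the scatter. Compound 3 is expected at 60000 nM, between 25000 nM and 150000 nM, most likely again as a limit.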

Compound 3, half-maximal inhibitory concentration: > 60000 nM
Compound 3: only a limit was reported; the forecaster's own chance of this, stated with the estimate: 80%; the middle value lies on the limit itself.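

Compound 2 and compound 3 are both reported only as limits, so no step between them can be read: the limit of > 60000 nM in this assay, at which 2 of the 3 values shown sit.

The compounds shown leave open whether prop-1-en-1-yl in place of vinyl on a carbonyl carbon alters inhibition at all in this assay.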